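Aryl-piperazine swap on the pentyl-linked saccharin core

The compounds below may be only part of what the source reports. "The series", "measured", "known", "first", "only" and "open" are said of these compounds alone.

Measured compounds:
compound 1 `O=C1c2ccccc2S(=O)(=O)N1CCCCCN1CCN(c2ccc(Cl)cc2)CC1` 191 nM
compound 2 `O=C1c2ccccc2S(=O)(=O)N1CCCCCCN1CCN(c2ncccn2)CC1` 2520 nM

In an assay on HEK293 cells for displacement of a labelled ligand from 5-hydroxytryptamine receptor 7 (Homo sapiens) (on this read-out lower numbers stand for stronger inhibition and higher numbers for weaker inhibition), compound 1 gives 191 nM, the lower of the two numbers; compound 2, which carries a pyrimidinyl group on a longer chain, gives 2520 nM, a gap that lies beyond the scatter. Among the measured compounds shown here, compound 1 and compound 2 differ in two places at once, so their two values show only that the pair is far apart, not which change carries the shift.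

Compound 3 `O=C1c2ccccc2S(=O)(=O)N1CCCCCN1CCN(c2ccccn2)CC1` is not yet measured. It differs from compound 1 in one place: pyridin-2-yl in place of 4-chlorophenyl on an amine nitrogen in a ring. For the measured compounds named here, no step between measured compounds isolates this exchange. Going by the values given here, the only reference is compound 2, whose value 2520 nM lies well above that of compound 1, and it is expected that a nitrogen-containing ring in place of 4-chlorophenyl moves compound 3 upward by a moderate step, a 3.4-fold higher number from compound 1 to compound 3 (0.53 log units; beyond the scatter). Compound 3 is estimated at 650 nM, within 200 nM to 2200 nM.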

Compound 3, inhibition constant: 179 nM
Estimate against measurement, compound 3: 3.6-fold (0.56 log units) above; the measured number lies below the stated range.
By their numbers in this assay, from the lowest: compounds 3 and 1 (each within the scatter of the next); then compound 2.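

In this assay, pyridin-2-yl in place of 4-chlorophenyl on an amine nitrogen in a ring gives a 1.1-fold lower number from compound 1 to compound 3 (0.03 log units; within the scatter), so this exchange leaves the read-out within the scatter. The earlier compounds shown here could not show this: at this position, a six-membered aromatic ring with 1 hetero atom and 1 hydrogen-bond acceptor reads alike with the carbon-only ring bearing chlorine, at least in this one pair on the pentyl-linked core. No measurement at hand bears on why the two groups read alike.

Compound 2 at 2520 nM differs from compound 3 in two places, so the share of its pyrimidinyl group and that of its longer chain remain unseparated. Also open, going by these compounds, is how this position responds to a phenyl ring bearing a methoxy group, or the core to a butyl chain.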